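The source may hold more compounds than are shown below. What is called first, only, known or untested is meant among the compounds shown, and "the series" means these compounds.

Measured compounds in an in vitro assay on LLC-PK1 cells for displacement of a labelled ligand from growth hormone secretagogue receptor type 1 (Homo sapiens); a lower number here means a stronger inhibitor, a higher number a weaker inhibitor:
Compound 1 `COc1ccc(-n2c(CCc3ccccc3)nnc2[C@H](NC(=O)Cc2ccccn2)c2c[nH]c3ccccc23)c(OC)c1` gives 120 nM in this assay.
Compound 2 `CCc1ccc(Cn2c(CCc3ccccc3)nnc2[C@H](NC(=O)Cc2ccccn2)c2c[nH]c3ccccc23)cc1` gives 51 nM in this assay.
Compound 3 `O=C(Cc1ccccn1)N[C@H](c1c[nH]c2ccccc12)c1nnc(CCc2ccccc2)n1-c1ccccc1` gives 700 nM in this assay.

Compound 2 has the lowest number of the three. The steps to the other two, a 2.4-fold lower number from compound 1 to compound 2 (0.37 log units; beyond the scatter) and a 14-fold higher number from compound 2 to compound 3 (1.14 log units; beyond the scatter), both lie beyond the scatter, so compound 2 is the strongest of the three measured compounds; the remaining step, a 5.8-fold higher number from compound 1 to compound 3 (0.77 log units; beyond the scatter), runs the same way. All three measured steps change only the group on the aromatic nitrogen of the shared core.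

Compound 4 `CCc1ccc(Cn2c(CCc3ccccc3)nnc2[C@H](NC(=O)c2cnccn2)c2c[nH]c3ccccc23)cc1` keeps the 4-ethylbenzyl of compound 2 and differs from it by pyrazin-2-yl in place of (pyridin-2-yl)methyl on a carbonyl carbon. For the measured compounds named here, no measured step touches the carbonyl carbon, so none of the steps bears directly on this change; the measured series gives no guide to its size or direction. The expectation is therefore a step within the scatter, a 1.6-fold higher number from compound 2 to compound 4 (0.20 log units; within the scatter), with wide uncertainty. Compound 4 is estimated at 80 nM in this assay, with a range from 20 nM to 400 nM.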

Compound 4, half-maximal inhibitory concentration: 89 nM
The estimate for compound 4 lay 1.1-fold (0.05 log units) below the measured number; the measured number falls inside the stated range.
By their numbers in this assay, from the lowest: compounds 2, 4 and 1 (each within the scatter of the next, the first and the last beyond it); then compound 3.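

In this assay, for the compounds shown here, the carbonyl carbon is varied for the first time, and pyrazin-2-yl in place of (pyridin-2-yl)methyl gives a 1.7-fold higher number from compound 2 to compound 4 (0.24 log units; within the scatter) with the 4-ethylbenzyl held constant. On this pair, then, the carbonyl substituent does not separate the two compounds, unlike the group on the aromatic nitrogen, where the steps among compounds 1, 2 and 3 all lie beyond the scatter. No measurement available here explains this result.

Going by these compounds alone, the single pair changes the ring and its connection to the carbonyl carbon together, so pyridin-2-yl attached directly to the carbonyl carbon would be needed to tell those two differences apart. Also open, on these data alone, is how a non-aromatic group on the carbonyl carbon, such as an amine or a longer alkyl chain, would read in this assay on this core.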